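A few compounds are considered here, and "the series" means these few. Any claim that something is new, unique, unknown or untested is made for them only; others in the source may bear on it.

Compound 1 `Cc1cc(/C=C/c2ccc(O)cc2)[nH]n1`: 32900 nM
Compound 2 `COc1ccc(/C=C/c2cc(C)n[nH]2)cc1`: 8400 nM
Compound 3 `COc1cc(/C=C/c2cc(C)[nH]n2)ccc1O`: 29400 nM

In a functional assay on S1 cells (Homo sapiens) for cytotoxicity, read by MTT assay, with a stated time of 72 h (on this read-out higher numbers stand for weaker inhibition and lower numbers for stronger inhibition), compound 1 sits at the high end of these numbers, which means weak inhibition. It shares that end with compound 3, since the two values lie within the usual scatter of each other. Compound 2 stands apart, with a 3.9-fold lower number from compound 1 to compound 2 (0.59 log units; beyond the scatter).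

Compound 4 `Cc1cc(/C=C/c2ccc(O)c(O)c2)[nH]n1` has not yet been measured. It comes from compound 1 by one change: hydroxy in place of hydrogen on an aromatic carbon. In words, this is hydroxy in place of hydrogen on an aromatic carbon.

Going by the values given here, no measured step makes this exact change. The nearest evidence is a 3.9-fold lower number from compound 1 to compound 2 (0.59 log units; beyond the scatter), a modest step that comes from methyl in place of hydrogen on an oxygen on an aromatic ring, so it offers only indirect guidance. The closeness of compound 1 at 32900 nM and compound 3 at 29400 nM shows that these values can stay together across different structures. Only a small move towards stronger inhibition is therefore expected, probably not beyond the scatter, and the estimated step is a 1.6-fold lower number from compound 1 to compound 4 (0.22 log units; within the scatter). For compound 4 the expected value is 20000 nM, with an estimated range from 8000 nM to 50000 nM.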

Compound 4, half-maximal inhibitory concentration: 55300 nM
Compound 4: the middle estimate sits 2.8-fold (0.44 log units) below what was measured; measured number outside the range, above it.
By their numbers in this assay, from the lowest: compound 2; then compounds 3, 1 and 4 (each within the scatter of the next).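

In this assay, a hydroxy group in place of hydrogen on an aromatic carbon, ortho to the existing hydroxy group, gives a 1.7-fold higher number from compound 1 to compound 4 (0.23 log units; within the scatter) and so makes no change that can be told from the scatter. Going by these compounds alone, this is the first look at this position of the six-membered aromatic ring, and it shows that a second hydroxy group here leaves compound 4 with compound 1 at the weak end of the numbers. Within the data shown here, the one step beyond the scatter remains a 3.9-fold lower number from compound 1 to compound 2 (0.59 log units; beyond the scatter) and comes from a change on the oxygen of the existing hydroxy group, not from a change at this carbon. No measurement shown here accounts for this result.

Still open, on these data alone, is whether a different group at this position, such as an amine or a carboxylic acid, would give a step beyond the scatter. As far as these compounds go, it is also open whether methyl in place of hydrogen on the oxygen of either hydroxy group of compound 4 would repeat the step seen with compound 2.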